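This account rests on a few compounds, and the source may have more. Where it says the series, first, only, none or still open, it means among the compounds named here.

Working notes on the series in a functional assay on BJAB cells (Homo sapiens) for antiproliferative activity, with a stated time of 4 days; a higher number here means that more compound is needed for the effect, a lower number that less compound is needed.

For the measured compounds named here, compound 2 `COc1cccc(-c2c(C)nn(-c3nc(-c4ccc(Cl)c(Cl)c4)c(SC(C)C)s3)c2C(=O)O)c1` holds the lowest of the two numbers measured so far, giving 14000 nM in this assay. Going by the values given here, its nearest neighbour is compound 1 `Cc1cccc(-c2c(C)nn(-c3nc(-c4ccc(Cl)c(Cl)c4)c(SC(C)C)s3)c2C(=O)O)c1`, which gives 17000 nM; the only measured step, a 1.2-fold lower number from compound 1 to compound 2 (0.08 log units; within the scatter), falls within the scatter, so the two compounds cannot be ordered against each other on these data.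

Compound 3 `Cc1nn(-c2nc(-c3ccc(Cl)c(Cl)c3)c(SC(C)C)s2)c(C(=O)O)c1-c1cc(C#N)cc(C(F)(F)F)c1` follows from compound 2 by 3-cyano-5-(trifluoromethyl)phenyl in place of 3-methoxyphenyl on an aromatic carbon. Among the compounds with values here, the single measured step touches the same ring position of the shared core, where a small change on the phenyl substituent left this assay flat. Within the data shown here, no measured step covers the exchange of the whole 3-methoxyphenyl for 3-cyano-5-(trifluoromethyl)phenyl, so the expectation for compound 3 rests on the flat step from compound 1 to compound 2 alone and carries a wide range.

Compound 3 is therefore expected to show a 1.2-fold lower number from compound 2 to compound 3 (0.07 log units; within the scatter), that is no step beyond the scatter. The estimate for compound 3 in this assay is 12000 nM, with a range from 4000 nM to 40000 nM.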

Compound 3, half-maximal effective concentration: 3600 nM
Beside the measured number, compound 3's estimate is 3.3-fold (0.52 log units) above it; measured number below the stated range.
By their numbers in this assay, from the lowest: compound 3; then compounds 2 and 1 (each within the scatter of the next).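

In this assay the aromatic carbon of the five-membered ring with 2 nitrogen looked flat while only 3-methylphenyl and 3-methoxyphenyl were compared, but it does respond to a larger exchange of the aryl group: 3-cyano-5-(trifluoromethyl)phenyl in place of 3-methoxyphenyl gives a 3.9-fold lower number from compound 2 to compound 3 (0.59 log units; beyond the scatter), and in place of 3-methylphenyl it gives a 4.7-fold lower number from compound 1 to compound 3 (0.67 log units; beyond the scatter). Both steps lie beyond the scatter and are modest in size, so compound 3 separates from the two earlier compounds, which remain within the scatter of each other, and the substituents on this phenyl ring are shown to matter in this assay. Nothing available explains the lower number of compound 3.

The compounds shown leave open whether the nitrile or the trifluoromethyl group accounts for the step, as the two enter together on one ring. They also leave open how far the trend extends at this position, for example to a phenyl ring bearing an amine, or whether a single nitrile or a single trifluoromethyl would hold the number of compound 3.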